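Shortening the Ester Chain on a Kinase Inhibitor

The compounds below may be only part of what the source reports. "The series", "measured", "known", "first", "only" and "open" are said of these compounds alone.

Compound 1 `CCCCCOC(=O)c1cccc(-c2cc(C(=O)Nc3ccncc3)ccc2CN)c1` was tested in an assay on isolated protein for inhibition of Rho-associated protein kinase 2 (Homo sapiens), read by radiometric assay (a higher number here means a weaker inhibitor, a lower number a stronger inhibitor), where compound 1 gives 4.9 nM. Its companion compound 2 `NCc1ccc(C(=O)Nc2ccncc2F)cc1-c1cccc(C(=O)OC2CCCOC2)c1` gives 8.7 nM in this assay. Within the data shown here, the two numbers lie within the scatter of each other, so compound 1 cannot be set apart from compound 2 on these data, and no step between the two is recorded here; only the two values themselves are known.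

The compound now to be examined is compound 3 `COC(=O)c1cccc(-c2cc(C(=O)Nc3ccncc3)ccc2CN)c1`, which differs from compound 1 by a single change: hydrogen in place of butyl on a saturated chain carbon bound to an oxygen next to a carbonyl group. The remainder of the molecule, the shared core with its amide and aminomethyl group, is untouched.

Among the measured compounds shown here, since no measured pair shows the effect of trimming this ester chain, the expectation rests on the two values alone. Compound 2, carrying a ring-bearing ester in the same position, gives a number close to that of compound 1, which suggests the ester substituent can be varied without a large shift. Compound 3 is therefore estimated at 10 nM, with a range of 3 nM to 35 nM, and the expected step is a 2.0-fold higher number from compound 1 to compound 3 (0.31 log units; beyond the scatter), a modest weakening of compound 3 that may not exceed the scatter.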

Compound 3, half-maximal inhibitory concentration: 2.9 nM
The estimate for compound 3 lay 3.4-fold (0.54 log units) above the measured number; the measured number lies below the stated range.
By their numbers in this assay, from the lowest: compounds 3, 1 and 2 (each within the scatter of the next, the first and the last beyond it).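

In this assay, among these compounds, this pair gives the first direct reading at this position: a 1.7-fold lower number from compound 1 to compound 3 (0.23 log units; within the scatter) lies within the scatter. Compound 3 therefore cannot be told apart from compound 1, so pentyloxycarbonyl and methoxycarbonyl read alike on the shared core, and removing the butyl with its 4 carbon atoms leaves no difference that these data can resolve. Compound 2 differs from compound 1 in more than one place and could not show this, whereas this pair isolates the ester chain alone, and no measurement is at hand that bears on why the two compounds read alike.

The compounds shown span only the two ends of this short series, so it stays open whether an ethyl or propyl ester, or a chain longer than pentyl, would also fall within the scatter of compound 1. Going by these compounds, it also stays open whether the ester itself can be exchanged at this place, for instance for a carboxylic acid or a primary amide, without a step beyond the scatter.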